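Removing the hydroxy group from compound 2

The source may report more compounds than this note shows. Statements on the series, on what has been measured and on what is new or still open speak of the compounds shown alone.

Compound 1 `COC(=O)N1N=C(c2ccccc2)CC1c1ccccc1`: > 10000 nM
Compound 2 `COC(=O)N1N=C(c2ccccc2)CC1c1ccc(OC)c(O)c1`: 7520 nM

These compounds were tested in a functional assay on HeLa cells (Homo sapiens) for antiproliferative activity, read by MTT assay, with a stated time of 48 h; on this read-out higher numbers stand for weaker inhibition of growth and lower numbers for stronger inhibition of growth. Compound 1 gives > 10000 nM, which is a limit of the assay and not a number. Among the measured compounds shown here, compound 2 gives 7520 nM, the only true number available so far, so there is no measured step to serve as a guide.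

The next compound, compound 3 `COC(=O)N1N=C(c2ccccc2)CC1c1ccc(OC)cc1`, keeps the methoxy group of compound 2 but loses its hydroxy: hydrogen in place of hydroxy on an aromatic carbon. In words, hydrogen stands in place of hydroxy on an aromatic carbon, ortho to a methoxy group.

Compound 1 also lacks the hydroxy, and its reading of > 10000 nM is again a limit. That result points toward weaker inhibition of growth for compound 3, which may also reach the limit in this assay. The estimated change is a 1.3-fold higher number from compound 2 to compound 3 (0.12 log units; within the scatter), a small step that is expected to lie within the usual scatter or only slightly beyond it. Compound 3 is expected at 10000 nM, with an estimated range from 5000 nM to 20000 nM.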

Compound 3, concentration for 50% growth inhibition: 12700 nM
Estimate against measurement, compound 3: 1.3-fold (0.10 log units) below; the range from low to high includes it.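

Among the compounds shown here, replacing the hydroxy with hydrogen on this aromatic carbon, ortho to a methoxy group, gives the first step in this assay that can be read as a number: a 1.7-fold higher number from compound 2 to compound 3 (0.23 log units; within the scatter). This step lies within the scatter, so compound 2 and compound 3 cannot be told apart in this assay, even though the hydroxy brings a hydrogen-bond donor and a hydrogen-bond acceptor that compound 3 lacks; on these numbers, the hydroxy makes no measurable difference at this position. Compound 1 stands at a limit of the assay and not at a number, so its step to compound 3, methoxy in place of hydrogen on an aromatic carbon, cannot be read: the limit of > 10000 nM in this assay, at which 1 of the 3 values shown sits.

The compounds shown leave open whether a different group on this aromatic carbon, such as an amine or a carboxylic acid, would give a number clearly apart from those of compound 2 and compound 3. Also open, going by these compounds, is what the methoxy group itself contributes, a question that a compound carrying the hydroxy alone could help to answer.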